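This account rests on a few compounds, and the source may have more. Where it says the series, first, only, none or still open, it means among the compounds named here.

Compound 1 `O=S(=O)(c1ccc(F)c(F)c1)c1cnc2cc(F)ccc2c1-c1ccc(Cl)cc1` and compound 2 `O=S(=O)(c1cc(Cl)cc(Cl)c1)c1cnc2cc(F)ccc2c1-c1ccc(Cl)cc1` share one core and were tested in an ADME assay on microsomes from liver (Homo sapiens) for metabolic stability, tested at 2.5 uM; on this read-out higher numbers stand for fast clearance and lower numbers for slow clearance. Compound 1 gives 0.01 mL/min, the lowest of the two numbers; compound 2 gives 0.13 mL/min. Among the measured compounds shown here, the one measured step, a 13-fold higher number from compound 1 to compound 2 (1.11 log units; beyond the scatter), comes from exchanging the ring on the sulfonyl sulfur and shows that a single ring swap can shift the read-out a long way.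

Compound 3 `COc1cccc(-c2c(S(=O)(=O)c3ccc(F)c(F)c3)cnc3cc(F)ccc23)c1` differs from compound 1 at another place: 3-methoxyphenyl in place of 4-chlorophenyl on an aromatic carbon. For the measured compounds named here, no measured step touches this position, so the step from compound 1 to compound 2 bears only indirectly, as a sign of how far one ring change can move the number. The expected step from compound 1 to compound 3 is therefore uncertain and is set as a modest rise, a 3.0-fold higher number from compound 1 to compound 3 (0.48 log units; beyond the scatter). Compound 3 is estimated in this assay at 0.03 mL/min, within a range from 0.008 mL/min to 0.12 mL/min.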

Compound 3, intrinsic clearance in a liver preparation (reported as CLH), per the amount of preparation that the assay uses: 1.77 mL/min
Compound 3: the middle estimate sits 59-fold (1.77 log units) below what was measured; measured number outside the range, above it.
By their numbers in this assay, from the lowest: compound 1; then compound 2; then compound 3.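

On the aromatic carbon opposite the ring nitrogen, replacing 4-chlorophenyl with 3-methoxyphenyl gives a 180-fold higher number from compound 1 to compound 3 (2.25 log units; beyond the scatter) in this assay, a larger step than the sulfonyl ring exchange, a 13-fold higher number from compound 1 to compound 2 (1.11 log units; beyond the scatter), so this position can move the read-out at least as far as that ring. The two groups differ both in the substituent and in its place on the phenyl ring, so this single step cannot separate the two changes. Nothing available explains the rise.

From the compounds shown here alone, it remains open whether 3-chlorophenyl or 4-methoxyphenyl would stay close to compound 1 or rise towards compound 3. Going by these compounds, how an amine or a carboxylic acid on this phenyl ring would behave in this read-out is also open.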